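The source may report more compounds than this note shows. Statements on the series, on what has been measured and on what is new or still open speak of the compounds shown alone.

Compound 1 `COc1ccc(Cn2cc(CSC(=S)N3CCN(C(=O)OCc4ccccc4)CC3)nn2)cc1`: in a functional assay on PC-3 cells (Homo sapiens) for inhibition, read by MTT assay, with a stated time of 72 h (a higher number here means a weaker inhibitor, a lower number a stronger inhibitor), compound 1 gives > 128000 nM, which is a limit of the assay.
Compound 2 `O=C(OCc1ccccc1)N1CCN(C(=S)SCc2cn(Cc3ccccc3F)nn2)CC1`: in this assay compound 2 gives 68300 nM.
Compound 3 `O=C(OCc1ccccc1)N1CCN(C(=S)SCc2cn(Cc3ccc(Cl)c(Cl)c3)nn2)CC1`: in this assay compound 3 gives > 128000 nM, which is a limit of the assay.

Compound 1 stands at the limit of > 128000 nM in this assay, at which 2 of the 3 values shown sit, so only a limit and no number is known for it. Compound 4 `COc1ccc(Cn2cc(CSC(=S)N3CCN(C(=O)OC(C)(C)C)CC3)nn2)cc1` differs from compound 1 by tert-butyl in place of benzyl on an oxygen next to a carbonyl group. Going by the values given here, none of the measured steps touches that place: an at least 1.8-fold lower number from compound 1 to compound 2 (0.27 log units; that floor lies within the scatter), a step that the two limits leave unreadable from compound 1 to compound 3 and an at least 1.8-fold higher number from compound 2 to compound 3 (0.27 log units; that floor lies within the scatter) all exchange the group on the saturated chain carbon bound to an aromatic nitrogen and leave the benzyloxycarbonyl unchanged, and two of those three steps run into the same limit. They therefore give no reading on the change from benzyl to tert-butyl, and no step beyond the scatter is expected in either direction. Compound 4 is expected to give about 150000 nM, with a range from 50000 nM to 500000 nM, most likely again reported only as a limit. The estimated step is a step that the limit leaves unreadable from compound 1 to compound 4, which is expected to stay within the scatter.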

Compound 4, half-maximal inhibitory concentration: > 128000 nM
Compound 4: only a limit was reported; the forecaster's own chance of this, stated with the estimate: 70%; the middle value is on the limit's open side.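

In this assay compound 4 gives > 128000 nM, which is a limit of the assay. Going by these compounds alone, compound 1 and compound 4 both rest on a limit, so no step between them can be read: the limit of > 128000 nM in this assay, at which 3 of the 4 values shown sit. The compounds shown leave open whether tert-butyl in place of benzyl changes inhibition at all.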